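Cytotoxicity Limits Across an Amide Series

This account rests on a few compounds, and the source may have more. Where it says the series, first, only, none or still open, it means among the compounds named here.

Compound 2 `O=C(CSc1snnc1-c1ccc(Br)cc1Br)Nc1cccnc1Cl` was examined in an ADME assay on MT4 cells (Homo sapiens) for cytotoxicity, read by MTT assay, with a stated time of 5 days; on this read-out higher numbers stand for lower toxicity in this test and lower numbers for higher toxicity in this test. In this assay compound 2 gives only a limit, > 240000 nM. Compound 1 `O=C(CSc1snnc1-c1ccc(Br)cc1Br)Nc1ccccc1[N+](=O)[O-]` likewise gives a limit in this assay, > 235000 nM. Compound 3 `CC(=O)c1ccc(NC(=O)CSc2snnc2-c2ccc(Br)cc2Br)c(Br)c1` also gives a limit in this assay, > 206000 nM. The step from compound 1 to compound 2 reads as a step that the two limits leave unreadable from compound 1 to compound 2. Compound 4 `Cc1ccccc1NC(=O)CSc1snnc1-c1ccc(Br)cc1Br` differs from compound 2 by 2-methylphenyl in place of 2-chloropyridin-3-yl on an amide-type nitrogen. For the measured compounds named here, no measured step bears on this change in a readable way; the limits (the limit of > 206000 nM in this assay, at which 1 of the 3 values shown sits), the limit of > 235000 nM in this assay, at which 1 of the 3 values shown sits, and the limit of > 240000 nM in this assay, at which 1 of the 3 values shown sits, show only that none of the measured compounds reached a number in this assay. Compound 4 is therefore expected to remain at the limit as well, with an estimated 240000 nM between 100000 nM and 500000 nM, an expected step of a number no higher from compound 2 to compound 4 (the limit leaves the size open).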

Compound 4, half-maximal cytotoxic concentration: 202000 nM
The estimate for compound 4 lay 1.2-fold (0.07 log units) above the measured number, and the stated range covers the measured number.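

Compound 4, with 2-methylphenyl on the amide-type nitrogen, is the only one of the compounds shown to give a number in this assay rather than a limit: compound 4 gives 202000 nM. The change from 2-chloropyridin-3-yl gives an at least 1.1-fold lower number from compound 2 to compound 4 (0.07 log units; that floor lies within the scatter), and methyl in place of nitro on an aromatic carbon gives an at least 1.1-fold lower number from compound 1 to compound 4 (0.06 log units; that floor lies within the scatter). Both steps are floors only, so neither establishes a change beyond the scatter.

The compounds shown leave open the full size of these steps. They also leave open whether an amine or a carboxylic acid in place of the methyl would give a lower number.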